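Methoxy to Ethoxy Across Two Related Cores

The compounds below may be only part of what the source reports. "The series", "measured", "known", "first", "only" and "open" are said of these compounds alone.

Compound 1 `CNc1nc(-c2cc(OC)c(OC)c(OC)c2)c(-c2ccc(OC)cc2)s1`: 138 nM
Compound 2 `CCOc1ccc(-c2sc(NC)nc2-c2cc(OC)c(OC)c(OC)c2)cc1`: 38.6 nM
Compound 3 `COc1ccc(-c2sc(N(C)C)nc2-c2cc(OC)c(OC)c(OC)c2)cc1`: reported only as a limit of this assay, > 10000 nM

In a functional assay on A549 cells (Homo sapiens) for antiproliferative activity, read by MTT assay, with a stated time of 72 h (a lower number here means a stronger inhibitor, a higher number a weaker inhibitor), compound 1 gives 138 nM and compound 2 gives 38.6 nM. The change between them is methyl in place of hydrogen on a saturated chain carbon bound to an oxygen on an aromatic ring, and it made a 3.6-fold lower number from compound 1 to compound 2 (0.55 log units; beyond the scatter). The two cores differ by methyl in place of hydrogen on a nitrogen on an aromatic ring, which made an at least 72-fold higher number from compound 1 to compound 3 (1.86 log units; beyond the scatter). Compound 3 stands at the limit of > 10000 nM in this assay, at which 1 of the 3 values shown sits.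

Compound 4 `CCOc1ccc(-c2sc(N(C)C)nc2-c2cc(OC)c(OC)c(OC)c2)cc1` carries the same change as compound 2, (methyl in place of hydrogen on a saturated chain carbon bound to an oxygen on an aromatic ring), on the core of compound 3. Since compound 3 is known only as a limit, the starting point is uncertain. The estimated step is an at least 1.2-fold lower number from compound 3 to compound 4 (0.09 log units; that floor lies within the scatter), resting on the modest earlier step of a 3.6-fold lower number from compound 1 to compound 2 (0.55 log units; beyond the scatter). Compound 4 is expected to give 8000 nM, between 2000 nM and 30000 nM.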

Compound 4, half-maximal inhibitory concentration: > 10000 nM
Compound 4: only a limit was reported; the forecaster's own chance of this, stated with the estimate: 60%; middle value at least 1.2-fold (0.09 log units) from the limit.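

In this assay compound 4 is reported only as a limit of the assay, > 10000 nM. With limits at both ends, the methoxy to ethoxy step on the core of compound 3 cannot be read, so these compounds do not show whether the lower number seen on the core of compound 1 carries over to that core. What can be read is the other change, methyl in place of hydrogen on a nitrogen on an aromatic ring, which gives an at least 250-fold higher number from compound 2 to compound 4 (2.41 log units; beyond the scatter), and it can be set beside the earlier step only as a floor: the same change on two cores in this assay, an at least 72-fold higher number (1.86 log units; beyond the scatter) from compound 1 to compound 3 and an at least 250-fold higher number (2.41 log units; beyond the scatter) from compound 2 to compound 4; the limit leaves it open whether they differ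

The compounds shown leave open how a longer chain such as propoxy reads on the core of compound 1. They also leave open how an ethyl group on that nitrogen would read.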